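The source may report more compounds than this note shows. Statements on the series, on what has been measured and on what is new or still open speak of the compounds shown alone.

Measured so far:
- compound 1, `Cc1cccc(Cc2cnc(CCc3ccc(-c4ccccc4C(=O)O)cc3)[nH]2)c1`, in an in vitro functional assay on cells for agonist activity at Bombesin receptor subtype-3 (Homo sapiens), read by luminescence and calcium flux (a higher number here means that more compound is needed for the effect, a lower number that less compound is needed), gives 4310 nM
- compound 2, `O=C(O)c1ccccc1-c1ccc(CCc2ncc(-c3ccccc3)[nH]2)cc1`, in this assay gives 4950 nM
- compound 3, `CC(C)(C)CCc1cnc(CCc2ccc(-c3ccccc3C(=O)O)cc2)[nH]1`, in this assay gives 39 nM

Compound 3 stands lowest of the three: the step of a 110-fold lower number from compound 1 to compound 3 (2.04 log units; beyond the scatter) and the step of a 130-fold lower number from compound 2 to compound 3 (2.10 log units; beyond the scatter) both lie far beyond the scatter, while a 1.1-fold higher number from compound 1 to compound 2 (0.06 log units; within the scatter) does not. In each of those two large steps an aromatic ring on the side chain of the shared core was replaced by a branched saturated chain, and the number fell sharply.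

Compound 4, `N#Cc1ccccc1Cc1cnc(CCc2ccc(-c3ccccc3C(=O)O)cc2)[nH]1`, reverses that kind of exchange: the difference from compound 3 is 2-cyanophenyl in place of neopentyl on a saturated chain carbon bound to an aromatic carbon. Among the measured compounds shown here, the aromatic ring that enters carries a nitrile, for which no measured compound gives guidance; the nearest comparison is compound 1, whose ring at this place carries a methyl instead. The steps from compound 1 and compound 2 to compound 3 therefore bear directly on this change, and a large rise in this assay is expected, roughly undoing them.

Compound 4 is estimated at 3000 nM, within 600 nM to 15000 nM, which means an expected step of a 77-fold higher number from compound 3 to compound 4 (1.89 log units; beyond the scatter).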

Compound 4, half-maximal effective concentration: 5480 nM
For compound 4 the middle estimate is 1.8-fold (0.26 log units) below the measured one; the range from low to high includes it.
By their numbers in this assay, from the lowest: compound 3; then compounds 1, 2 and 4 (each within the scatter of the next).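

In this assay the step of a 140-fold higher number from compound 3 to compound 4 (2.15 log units; beyond the scatter) is large, whereas a 1.3-fold higher number from compound 1 to compound 4 (0.10 log units; within the scatter) and a 1.1-fold higher number from compound 2 to compound 4 (0.04 log units; within the scatter) both stay within the scatter. A nitrile on the ring therefore leaves compound 4 in the same range as compound 1, with its methyl-bearing ring, and compound 2, with its plain phenyl, so that among these four only the 3,3-dimethylbutyl chain of compound 3 stands apart. Nothing available explains this gap between the saturated chain and the aromatic groups.

The compounds shown cannot separate the loss of the aromatic ring from the presence of branching, since they include neither a straight pentyl chain nor a saturated ring such as cyclohexylmethyl. On these data alone, it also remains open whether a chain carrying an amine or a hydroxyl group would keep a number close to that of compound 3 at 39 nM.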